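Swapping the chlorophenyl arm for a furan ring

The compounds below may be only part of what the source reports. "The series", "measured", "known", "first", "only" and "open" are said of these compounds alone.

Of the compounds shown here, two sharing one core have been measured in a functional assay on U-251 cells (Homo sapiens) for antiproliferative activity, read by MTT assay, with a stated time of 48 h; a lower number here means a stronger inhibitor, a higher number a weaker inhibitor. Compound 1, `COc1cc(-c2cccc3nc(-c4ccc(F)cc4)oc23)cc(OC)c1OC`, gives only a limit of the assay, > 25000 nM. Going by the values given here, compound 2, `COc1cc(-c2cccc3nc(-c4ccc(Cl)cc4)oc23)cc(OC)c1OC`, gives 1600 nM, which is the only numerical result so far, so compound 2 stands as the one compound with a defined value. Among the compounds with values here, the single measured step, an at least 15-fold lower number from compound 1 to compound 2 (1.19 log units; beyond the scatter), shows that a change at the aromatic ring on the core moves the result strongly; on that evidence the value of compound 1 sits at the limit of > 25000 nM in this assay, at which 1 of the 2 values shown sits.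

Compound 3, `COc1cc(-c2cccc3nc(-c4ccco4)oc23)cc(OC)c1OC`, differs from compound 2 as follows: furan-2-yl in place of 4-chlorophenyl on an aromatic carbon. Within the data shown here, no measured step covers this exchange directly. Since the measured change at this same position was large, a large step is plausible here too, and the estimate leans toward a weaker inhibitor. Compound 3 is expected to give about 6000 nM, between 1500 nM and 25000 nM, which is the expected step of a 3.8-fold higher number from compound 2 to compound 3 (0.57 log units; beyond the scatter).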

Compound 3, half-maximal inhibitory concentration: 10600 nM
The estimate for compound 3 lay 1.8-fold (0.25 log units) below the measured number, and the stated range covers the measured number.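

In this assay, furan-2-yl in place of 4-chlorophenyl gives a 6.6-fold higher number from compound 2 to compound 3 (0.82 log units; beyond the scatter), so this position keeps a measurable result with a smaller, five-membered aromatic ring carrying one oxygen. Furan-2-yl in place of 4-fluorophenyl gives an at least 2.3-fold lower number from compound 1 to compound 3 (0.37 log units; beyond the scatter), so the furan-2-yl arm ranks between the two halogenated phenyl arms, and a six-membered carbon ring at this place does not by itself give the better result. Compound 1 remains a limit of the assay, not a number: the limit of > 25000 nM in this assay, at which 1 of the 3 values shown sits.

The compounds shown leave open how a thiophen-2-yl or pyridinyl ring would compare with furan-2-yl at this place. They also leave open whether an unsubstituted phenyl, or a phenyl carrying an amine or a carboxylic acid, would follow 4-chlorophenyl or 4-fluorophenyl.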